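This account rests on a few compounds, and the source may have more. Where it says the series, first, only, none or still open, it means among the compounds named here.

Three compounds have been measured in an assay on membranes from brain for binding affinity to Monoglyceride lipase (Mus musculus), read by fluorescence, with stated times of 1 h and 30 min; on this read-out lower numbers stand for stronger inhibition and higher numbers for weaker inhibition:

Compound 1 `O=C(N1CCCN(Cc2ccc(OCc3ccccc3)cc2)CC1)n1cccn1` gives 10000 nM.
Compound 2 `N#Cc1cnn(C(=O)N2CCCN(Cc3ccc(OCc4ccccc4)cc3)CC2)c1` gives 10000 nM.
Compound 3 `O=C(NCc1ccc(OC(c2ccccc2)c2ccccc2)cc1)n1cccn1` gives only a limit of this assay, > 100000 nM, and no number.

Compound 1 and compound 2 share one core and differ in a single place: cyano in place of hydrogen on an aromatic carbon. On this core the change leaves the measured value where it was, since the step of no change at the digits printed from compound 1 to compound 2 (within the scatter) is within the usual scatter. Compound 3 sits at a limit of this assay, the one described by the limit of > 100000 nM in this assay, at which 1 of the 3 values shown sits. How the core of compound 3 differs from the core of compound 1 is not broken down here.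

Compound 4 `N#Cc1cnn(C(=O)NCc2ccc(OC(c3ccccc3)c3ccccc3)cc2)c1` is not yet measured. It carries the same change, made on the core of compound 3: cyano in place of hydrogen on an aromatic carbon. Since on compound 1 the cyano group produced the step of no change at the digits printed from compound 1 to compound 2 (within the scatter), the expected step from compound 3 to compound 4 in this assay is a step that the limit leaves unreadable from compound 3 to compound 4, and compound 4 is expected to remain at a limit of the assay rather than give a number. The estimate for compound 4 is 150000 nM, with a range from 50000 nM to 500000 nM.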

Compound 4, half-maximal inhibitory concentration: > 100000 nM
Compound 4: no number, only a limit; the forecaster's own chance of this, stated with the estimate: 80%; the middle value is on the limit's open side.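

Compound 4 gives only a limit of this assay, > 100000 nM, and no number. Going by these compounds alone, compound 3 also gives only a limit, > 100000 nM, so no step from compound 3 to compound 4 can be read. The compounds shown leave open whether the cyano group changes the value at all on the core of compound 3.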